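The source may report more compounds than this note shows. Statements on the series, on what has been measured and on what is new or still open speak of the compounds shown alone.

Three close analogues of one core have been examined in an assay on HEK293 cells for displacement of a labelled ligand from adenosine receptor A2b (Homo sapiens), read by radioligand binding, with a stated time of 30 min, tested at 1 uM; a lower number here means less inhibition, a higher number more inhibition at the concentration tested (going by the name of the read-out). Compound 1 `CC1=C(C(=O)OC(C(F)(F)F)C(F)(F)F)C(c2ccoc2)NC(=O)N1` gives 2% in this assay. Compound 2 `CC1=C(C(=O)OC(C(F)(F)F)C(F)(F)F)C(c2ccsc2)NC(=O)N1` gives 1%, and compound 3 `CC1=C(C(=O)OC(C)C(F)(F)F)C(c2ccsc2)NC(=O)N1` gives 1%. Compound 2 therefore sits at the same reading as compound 3, and the reading of compound 1 lies within the scatter of it; all three numbers are indistinguishable from one another.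

The step of a number 1 percentage points lower from compound 1 to compound 2 (within the scatter) exchanges one five-membered heteroaryl for another on the saturated ring carbon, and the step of no change at the digits printed from compound 2 to compound 3 (within the scatter) alters the ester side; neither moves the reading.

Compound 4 `CC1=C(C(=O)OC(C(F)(F)F)C(F)(F)F)C(c2ccco2)NC(=O)N1` differs from compound 2 in the same position as the first of those steps: furan-2-yl in place of thiophen-3-yl on a saturated ring carbon. The step from compound 1 to compound 2 is the one that bears directly on this change, since it too swaps one five-membered aromatic ring with one hetero atom for another on the saturated ring carbon, and it stayed within the scatter. With nothing in the measured steps pointing to a shift, the change is expected to leave the reading where it stands, so the estimated step is a number 1 percentage points higher from compound 2 to compound 4 (within the scatter). Compound 4 is thus expected to give about 2% in this assay, within a range from -5% to 10%.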

Compound 4, a percentage reported as inhibition, at one concentration (the size of the read-out at that concentration, not a potency): 1%
The estimate for compound 4 lay 1 percentage points above the measured number, within the range that was stated.
By their numbers in this assay, from the lowest: compounds 2, 3, 4 and 1 (each within the scatter of the next).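

Until now, the saturated ring carbon had carried only furan-3-yl and thiophen-3-yl, so furan-2-yl adds a third five-membered aromatic ring with one hetero atom, joined to the core through a different ring position, and in this assay the change from thiophen-3-yl gives no change at the digits printed from compound 2 to compound 4 (within the scatter), a swap that alters both the hetero atom and the point of attachment at once. The comparison that keeps the hetero atom and alters only the point of attachment gives a number 1 percentage points lower from compound 1 to compound 4 (within the scatter), so neither kind of exchange at this position separates the readings, and all the ring exchanges tested here stay within the scatter. No measured information accounts for this outcome or explains what it means at the level of the receptor.

The compounds shown leave open whether any group of a different kind on this saturated ring carbon, such as an amine, a carboxylic acid or a longer chain, would give a reading beyond the scatter. They also leave open whether furan-2-yl would give the same reading when methyl replaces trifluoromethyl on the ester side, as it does in compound 3.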